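The source may hold more compounds than are shown below. What is called first, only, known or untested is meant among the compounds shown, and "the series" means these compounds.

Of the compounds shown here, three built on one shared core have been measured in an assay on isolated protein (strain Sprague-Dawley) for inhibition of Amine oxidase [flavin-containing] A (Rattus norvegicus), read by spectrophotometry, with a stated time of 5 min, tested at 10 uM; on this read-out higher numbers stand for more inhibition at the one concentration tested (going by the name of the read-out) and lower numbers for less inhibition. Compound 3 `O=c1cc(CCl)c2ccc(OCc3cccc(Cl)c3)cc2o1` gives 21%, compound 1 `CC(C)Oc1cc(=O)oc2cc(OCc3cccc(Cl)c3)ccc12` gives 3%, and compound 2 `O=C(O)COc1cc(=O)oc2cc(OCc3cccc(Cl)c3)ccc12` gives 0%. Compound 3 stands highest of the three: a number 18 percentage points higher from compound 1 to compound 3 (beyond the scatter) and a number 21 percentage points higher from compound 2 to compound 3 (beyond the scatter), while compound 1 and compound 2 sit within the scatter of each other, a number 3 percentage points lower from compound 1 to compound 2 (within the scatter).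

Compound 4 `CCOC(=O)c1cc(=O)oc2cc(OCc3cccc(Cl)c3)ccc12` has not yet been measured. It differs from compound 3 in one place: ethoxycarbonyl in place of chloromethyl on an aromatic carbon. The two steps that bear on this change are the ones leading to compound 3, where swapping an oxygen-linked group for chloromethyl raised the read-out in this assay by a modest but real amount, a number 18 percentage points higher from compound 1 to compound 3 (beyond the scatter) and a number 21 percentage points higher from compound 2 to compound 3 (beyond the scatter). Here the chloromethyl leaves again and an oxygen-bearing group enters, so the expectation is a modest fall, a number 15 percentage points lower from compound 3 to compound 4 (beyond the scatter), back toward the level of compound 1 and compound 2. Compound 4 is therefore expected to give about 6%, with a likely range from 0% to 20%.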

Compound 4, a percentage reported as inhibition, at one concentration (the size of the read-out at that concentration, not a potency): 4.4%
The estimate for compound 4 lay 1.6 percentage points above the measured number; the range from low to high includes it.
By their numbers in this assay, from the lowest: compounds 2, 1 and 4 (each within the scatter of the next); then compound 3.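

Ethoxycarbonyl joins the shared core through a carbon atom, as chloromethyl does, yet it does not keep the higher reading in this assay, with a number 16.6 percentage points lower from compound 3 to compound 4 (beyond the scatter), so a carbon link at this position is not enough for that reading. It also reads level with the two oxygen-linked groups, with a number 1.4 percentage points higher from compound 1 to compound 4 (within the scatter) and a number 4.4 percentage points higher from compound 2 to compound 4 (within the scatter), so among these four compounds, low readings at this position do not depend on an oxygen link, and only compound 3 stands apart. No measured evidence here explains what sets chloromethyl apart from the other three groups.

From the compounds shown here alone, whether the chlorine matters remains open, since a plain methyl or a bromomethyl group at this position would be needed to test it. Going by these compounds, how an amine or a longer carbon chain would read here also remains open.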